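A Pyridine Ring in Place of the Methylphenyl Group

A few compounds are considered here, and "the series" means these few. Any claim that something is new, unique, unknown or untested is made for them only; others in the source may bear on it.

Within the data shown here, in a functional assay on IMR-32 cells (Homo sapiens) for cytotoxicity, read by sulforhodamine B assay, with a stated time of 48 h (a lower number here means a stronger inhibitor, a higher number a weaker inhibitor), compound 2 `CC1=C(/C=C/C(=O)/C=C/c2ccc(C)cc2)C(C)(C)CCC1` gives 19200 nM, the second highest of the three numbers measured so far. Compound 1 `CC1=C(/C=C/C(=O)/C=C/c2ccc(C#N)cc2)C(C)(C)CCC1` gives 23400 nM and compound 3 `CC1=C(/C=C/C(=O)/C=C/c2ccc([N+](=O)[O-])cc2)C(C)(C)CCC1` gives 3200 nM. The step of a 1.2-fold lower number from compound 1 to compound 2 (0.09 log units; within the scatter) lies within the scatter, whereas a 6.0-fold lower number from compound 2 to compound 3 (0.78 log units; beyond the scatter) and a 7.3-fold lower number from compound 1 to compound 3 (0.86 log units; beyond the scatter) are modest. Compound 4 `CC1=C(/C=C/C(=O)/C=C/c2cccnc2)C(C)(C)CCC1` differs from compound 2 in one place: pyridin-3-yl in place of 4-methylphenyl on a double-bonded chain carbon bound to a double-bonded chain carbon. Among the measured compounds shown here, none of the measured steps exchanges the aromatic ring itself; they only vary the group carried on it, and exchanging methyl for cyano changed little. So in this assay no step beyond the scatter is expected, with a wide range either way. Compound 4 is therefore estimated at 20000 nM, between 6000 nM and 60000 nM, an expected step of a 1.0-fold higher number from compound 2 to compound 4 (0.02 log units; within the scatter).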

Compound 4, half-maximal inhibitory concentration: 25300 nM
Beside the measured number, compound 4's estimate is 1.3-fold (0.10 log units) below it; the measured number falls inside the stated range.
By their numbers in this assay, from the lowest: compound 3; then compounds 2, 1 and 4 (each within the scatter of the next).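

Exchanging the aromatic ring itself on the double-bonded chain carbon, and not just the group it carries, gives a 1.3-fold higher number from compound 2 to compound 4 (0.12 log units; within the scatter) in this assay. So a ring nitrogen, with its one hydrogen-bond acceptor, can replace the 4-methylphenyl carbon ring without a change beyond the scatter. No measurement here offers an explanation for this result.

Still open, as far as these compounds go, is whether a pyridine ring carrying a nitro group would match the number of compound 3. From the compounds shown here alone, how an amine or a carboxylic acid on the aromatic ring would behave also remains unknown.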